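From ethoxycarbonyl to formyl, starting at a limit

This account rests on a few compounds, and the source may have more. Where it says the series, first, only, none or still open, it means among the compounds named here.

Measured so far in a functional assay with Cavia porcellus as the target; a lower number here means tighter binding, a higher number weaker binding:
- compound 1 `COC(=O)c1ccccc1OCC(O)CNCCNC(=O)C(C)C`: 7.94 nM
- compound 2 `COC(=O)c1ccccc1OCC(O)CNCCNS(=O)(=O)c1ccc(C)cc1`: 158 nM
- compound 3 `CCOC(=O)N1CCC(=NCC(O)COc2ccccc2C(=O)OC)CC1`: > 1000 nM (a limit, not a number)

Compound 3 is the starting point here, and its entry of > 1000 nM is a limit of the assay rather than a number. Compound 1 and compound 2 both have true numbers, and both are lower than that limit, so they bind more tightly in this assay.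

Compound 4 `COC(=O)c1ccccc1OCC(O)CN=C1CCN(C=O)CC1` has not been measured yet. It differs from compound 3 in one place: hydrogen in place of ethoxy on a carbonyl carbon. That is hydrogen in place of ethoxy on a carbonyl carbon whose other neighbours are: amide-type nitrogen in a ring. Cut one bond further out, ethoxycarbonyl becomes formyl.

Within the data shown here, no measured pair of compounds shows this change, so the data offer no direct guide to its size. The nearest relative is compound 3, so the expectation is no shift beyond the scatter, and compound 4 may also end up reported only as a limit. The expected change is a step that the limit leaves unreadable from compound 3 to compound 4, which is only an estimate. For compound 4 the estimated dissociation constant is 1500 nM, with an expected range from 300 nM to 6000 nM.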

Compound 4, dissociation constant: > 1000 nM
Compound 4 was reported as a limit (the forecaster's own chance of this, stated with the estimate: 65%); the middle value does not contradict the limit.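

No step can be read from compound 3 to compound 4, as both are reported only as limits and not as numbers. Left open is how tightly either compound binds in this assay and whether going from ethoxycarbonyl to formyl changes that binding at all, because both entries stop at the same point: the limit of > 1000 nM in this assay, at which 2 of the 4 values shown sit.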